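A few compounds are considered here, and "the series" means these few. Any claim that something is new, unique, unknown or untested is made for them only; others in the source may bear on it.

Compound 3 `CCN(CC)c1cc2[nH]c(C3CCCCC3)nc2cc1NC(=O)c1ccc(OC(F)(F)F)cc1` stands in an ADME assay on Vero cells (Chlorocebus sabaeus) for cytotoxicity, read by resazurin assay, with a stated time of 3 days (a higher number here means a weaker inhibitor, a lower number a stronger inhibitor), only at a limit. In this assay compound 3 gives > 100 ug/mL, a limit of the assay rather than a number. Compound 1 `CCCCNC(=O)Nc1cc2nc(C3CCCCC3)[nH]c2cc1N(CC)CC` likewise gives only a limit in this assay, > 100 ug/mL. Compound 2 `CCN(CC)c1cc2[nH]c(C3CCCCC3)nc2cc1NC(=O)c1ccc(N(C)C)cc1` has no result in this assay, "not determined" (no result reported). The step that the two limits leave unreadable from compound 1 to compound 3 therefore cannot be read in size. Compound 4 `CCCC(C)OC(=O)Nc1cc2nc(C3CCCCC3)[nH]c2cc1N(CC)CC` differs from compound 3 by 1-methylbutoxy in place of 4-(trifluoromethoxy)phenyl on a carbonyl carbon. Within the data shown here, no measured step of readable size bears on this change. Among the measured compounds shown here, the only evidence is the limit of > 100 ug/mL in this assay, at which 2 of the 3 values shown sit. On that basis no step beyond the scatter is expected in this assay. The step of a number no higher from compound 3 to compound 4 (the limit leaves the size open) is expected to land again at the limit. Compound 4 is estimated at 100 ug/mL, between 50 ug/mL and 200 ug/mL.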

Compound 4, half-maximal inhibitory concentration: > 100 ug/mL
Compound 4 was reported as a limit; the forecaster's own chance of this, stated with the estimate: 85%; the middle value lies on the limit itself.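

In this assay compound 4 gives > 100 ug/mL, a limit rather than a number, and neither step to it, from compound 1 or from compound 3, can be read. The compounds shown leave open whether the group on the carbonyl carbon alters cytotoxicity at all.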